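Swapping Methyl for Chloro on the Benzyl Ether

This account rests on a few compounds, and the source may have more. Where it says the series, first, only, none or still open, it means among the compounds named here.

Compound 2 `COc1cc(OC)c(-c2coc3cc(OCc4ccccc4C)ccc3c2=O)cc1OC` gives 1860 nM in a functional assay on HepG2 cells (Homo sapiens) for antiproliferative activity, read by MTT assay, with a stated time of 24 h (on this read-out lower numbers stand for stronger inhibition and higher numbers for weaker inhibition), the highest of the two numbers recorded so far. Going by the values given here, its only neighbour, compound 1 `COc1cc(OC)c(-c2coc3cc(OCC=C(C)C)ccc3c2=O)cc1OC`, gives 280 nM in this assay, and the single measured step is a 6.6-fold higher number from compound 1 to compound 2 (0.82 log units; beyond the scatter). Compound 3 `COc1cc(OC)c(-c2coc3cc(OCc4ccccc4Cl)ccc3c2=O)cc1OC` awaits measurement. It differs from compound 2 by chloro in place of methyl on an aromatic carbon. Among the compounds with values here, no measured step touches a substituent on that phenyl ring: the step from compound 1 to compound 2 exchanges the whole group on the chain carbon, so its size says little about a one-atom swap on the ring. With nothing in the data bearing directly on this exchange, the step expected in this assay is one of no more than the usual scatter, in either direction, a 1.2-fold lower number from compound 2 to compound 3 (0.09 log units; within the scatter). Compound 3 is therefore estimated at 1500 nM, with a range from 600 nM to 4500 nM.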

Compound 3, half-maximal inhibitory concentration: 1690 nM
Beside the measured number, compound 3's estimate is 1.1-fold (0.05 log units) below it; low and high end bracket the measured number.
By their numbers in this assay, from the lowest: compound 1; then compounds 3 and 2 (each within the scatter of the next).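

At this place, on an aromatic carbon ortho to a large group, chloro in place of methyl gives a 1.1-fold lower number from compound 2 to compound 3 (0.04 log units; within the scatter) in this assay, so this first measured change on the phenyl ring leaves the read-out where it stood. With 2-chlorophenyl in place of 2-methylprop-1-en-1-yl the step is a 6.0-fold higher number from compound 1 to compound 3 (0.78 log units; beyond the scatter), much the same in size as a 6.6-fold higher number from compound 1 to compound 2 (0.82 log units; beyond the scatter), so compound 1 stays apart from both compounds carrying a substituted benzyl group. No evidence is available on why methyl and chloro read alike here. The compounds shown leave open whether a group with other atoms at this place, such as methoxy, an amine or a carboxylic acid, would also leave the number unmoved. They also leave open how the unsubstituted benzyl ether would compare.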